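A few compounds are considered here, and "the series" means these few. Any claim that something is new, unique, unknown or untested is made for them only; others in the source may bear on it.

Measured so far:
compound 1 `O=C(Nc1ccc(F)c(-c2nc3ncc(-c4ccc(F)c(F)c4)cc3[nH]2)c1)N1CCCC1` gives 12000 ng.h/mL
compound 2 `O=C(Nc1ccc(F)c(-c2nc3ncc(-c4cc(F)ccc4F)cc3[nH]2)c1)N1CCCC1` gives 5620 ng.h/mL
compound 3 `O=C(Nc1ccc(F)c(-c2nc3ncc(-c4cccc(F)c4F)cc3[nH]2)c1)N1CCCC1` gives 4750 ng.h/mL

In an ADME assay on the whole organism (Mus musculus, strain Swiss Webster) for pharmacokinetics, read by LC-MS, at a dose of 50 mg/kg by the oral route (a higher number here means more compound in the circulation at the dose given, a lower number less compound in the circulation), compound 1 stands highest of the three numbers; its nearest neighbour is compound 2 and its furthest is compound 3, and both steps away from it lie beyond the scatter.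

Compound 4 `O=C(Nc1ccc(F)c(-c2nc3ncc(-c4cccnc4F)cc3[nH]2)c1)N1CCCC1` differs from compound 1 in one place: 2-fluoropyridin-3-yl in place of 3,4-difluorophenyl on an aromatic carbon. For the measured compounds named here, no measured step carries this exact change. The two steps that bear on it leave compound 1 and rearrange the fluorines on the same ring: a 2.1-fold lower number from compound 1 to compound 2 (0.33 log units; beyond the scatter) and a 2.5-fold lower number from compound 1 to compound 3 (0.40 log units; beyond the scatter). Both are modest and both point downward, while between the two rearranged rings the difference is small, a 1.2-fold lower number from compound 2 to compound 3 (0.07 log units; within the scatter). The change to compound 4 goes further than either, since it replaces the ring itself rather than the fluorine pattern, so the direction cannot be read from these steps with any confidence; the balance of the series suggests a modest drop rather than a gain.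

For compound 4 the expectation in this assay is 7000 ng.h/mL, with a range from 3000 ng.h/mL to 16000 ng.h/mL, which would mean an expected step of a 1.7-fold lower number from compound 1 to compound 4 (0.23 log units; within the scatter).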

Compound 4, area under the concentration-time curve: 30900 ng.h/mL
Estimate against measurement, compound 4: 4.4-fold (0.64 log units) below; measured number outside the range, above it.
By their numbers in this assay, from the lowest: compounds 3 and 2 (each within the scatter of the next); then compound 1; then compound 4.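

In this assay, for the compounds shown here, the ring on this aromatic carbon, two atoms from the ring nitrogen, can raise the number as well as lower it: 2-fluoropyridin-3-yl in place of 3,4-difluorophenyl gives a 2.6-fold higher number from compound 1 to compound 4 (0.41 log units; beyond the scatter), the only upward step from compound 1, and compound 4 holds the highest number of the four. Measured against the other two fluorine patterns, the same kind of ring change gives a 6.5-fold higher number from compound 3 to compound 4 (0.81 log units; beyond the scatter) and a 5.5-fold higher number from compound 2 to compound 4 (0.74 log units; beyond the scatter), the largest steps in the series, so replacing the ring itself reaches a range that compound 1, compound 2 and compound 3 gave no sign of. Going by these compounds alone, no measurement on these compounds speaks to the origin of the rise.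

The change brings in a ring nitrogen and removes a fluorine at once, and these compounds do not separate the two; a plain pyridin-3-yl ring, a 2-chloropyridin-3-yl ring or a 2-aminopyridin-3-yl ring would bear on that question. Also open, going by these compounds, is whether the higher number reflects uptake or removal from the circulation, and whether it holds at other doses or by other routes.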